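Nitro for bromo on the ether of compound 1

The source may report more compounds than this note shows. Statements on the series, on what has been measured and on what is new or still open speak of the compounds shown alone.

Measured so far in an assay on CHO cells for displacement of a labelled ligand from adenosine receptor A3 (Homo sapiens), read by radioligand binding; a higher number here means a weaker inhibitor, a lower number a stronger inhibitor:
compound 1 `CCOc1cccc2cc(-c3ccc(Br)cc3)c(=O)oc12` — > 100000 nM
compound 2 `O=c1oc2c(O)cccc2cc1-c1ccc(Br)cc1` — 258 nM

In this assay compound 1 gives > 100000 nM, which is a limit of the assay and not a number. Compound 1 therefore stands at the limit of > 100000 nM in this assay, at which 1 of the 2 values shown sits, with no measured value of its own. In this assay compound 2 gives 258 nM. Among the compounds with values here, the only measured step, an at least 380-fold lower number from compound 1 to compound 2 (2.58 log units; beyond the scatter), starts from that limit and changes a different part of the shared core.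

Compound 3 `CCOc1cccc2cc(-c3ccc([N+](=O)[O-])cc3)c(=O)oc12` differs from compound 1 by nitro in place of bromo on an aromatic carbon. Within the data shown here, none of the measured steps bears on an exchange at this place; the one step known, an at least 380-fold lower number from compound 1 to compound 2 (2.58 log units; beyond the scatter), concerns another position. With compound 1 at the limit and no guidance on nitro in place of bromo, compound 3 is expected to stay near that limit, and the step of a number no higher from compound 1 to compound 3 (the limit leaves the size open) is expected to be none beyond the scatter. Compound 3 is thus estimated at 100000 nM, between 20000 nM and 300000 nM.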

Compound 3, inhibition constant: > 100000 nM
Compound 3: only a limit was reported; the forecaster's own chance of this, stated with the estimate: 70%; the middle value lies on the limit itself.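

In this assay compound 3 gives > 100000 nM, a limit of the assay and not a number. Within the data shown here, compound 1 also stands at a limit, and no step between compound 1 and compound 3 can be read. The compounds shown leave open what nitro in place of bromo does to the number in this assay, with ethyl or with hydrogen on that oxygen.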